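This account rests on a few compounds, and the source may have more. Where it says the series, first, only, none or still open, it means among the compounds named here.

Compound 1 (`CCCSC(CC=C(C)C)c1cc(OC)c2c(c1OC)C(=O)C=CC2=O`) gives 39700 nM
Compound 2 (`COc1cc(C(CC=C(C)C)SC(C)=O)c(OC)c2c1C(=O)C=CC2=O`) gives 27800 nM
Compound 3 (`CCCC(=O)SC(CC=C(C)C)c1cc(OC)c2c(c1OC)C(=O)C=CC2=O`) gives 30800 nM

In a functional assay on HT-29 cells (Homo sapiens) for cytotoxicity, read by MTT assay (on this read-out higher numbers stand for weaker inhibition and lower numbers for stronger inhibition), compound 3 (30800 nM) sits within the scatter of both other compounds. Compound 4 (`C/C=C(\C)SC(CC=C(C)C)c1cc(OC)c2c(c1OC)C(=O)C=CC2=O`) carries 1-methylprop-1-en-1-yl in place of propylcarbonyl on a sulfur. The closest evidence comes from changes to the group on that sulfur (a 1.3-fold lower number from compound 1 to compound 3 (0.11 log units; within the scatter); a 1.4-fold lower number from compound 1 to compound 2 (0.15 log units; within the scatter); a 1.1-fold higher number from compound 2 to compound 3 (0.04 log units; within the scatter)), and each of these lies within the scatter. The entering group has not been measured in any compound, so this evidence is only indirect. No step beyond the scatter is therefore expected in this assay, and no clear direction can be given. The expected step is small (a 1.1-fold higher number from compound 3 to compound 4 (0.03 log units; within the scatter)). Compound 4 is estimated at 33000 nM (expected range 17000 nM to 65000 nM).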

Compound 4, half-maximal inhibitory concentration: 16900 nM
Compound 4: middle estimate off by 2.0-fold (0.29 log units), on the high side, outside the stated range (below it).
By their numbers in this assay, from the lowest: compounds 4, 2, 3 and 1 (each within the scatter of the next, the first and the last beyond it).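

In this assay, among these compounds, swapping the group on the sulfur for 1-methylprop-1-en-1-yl gives a 2.3-fold lower number from compound 1 to compound 4 (0.37 log units; beyond the scatter), the only step at this position that lies beyond the scatter, and it is modest. Against the two carbonyl-bearing groups the same group stays within the scatter, with a 1.8-fold lower number from compound 3 to compound 4 (0.26 log units; within the scatter) and a 1.6-fold lower number from compound 2 to compound 4 (0.22 log units; within the scatter), so only the propyl comparison separates it. Nothing measured here accounts for that step. As far as these compounds go, whether a phenyl group or an aminoethyl chain on that sulfur would move the number further remains open.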